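The compounds below may be only part of what the source reports. "The series", "measured", "known", "first", "only" and "open" are said of these compounds alone.

Measured compounds:
compound 1, `CCCCCC(C#CC(=O)OC)O/C=C/C(=O)OC`: 1900 nM
compound 2, `C#CCO/C=C/C(=O)OC`: > 100000 nM

Among the measured compounds shown here, in a functional assay on HBL-100 cells (Homo sapiens) for antiproliferative activity, read by sulforhodamine B assay, with a stated time of 48 h (on this read-out lower numbers stand for stronger inhibition of growth and higher numbers for weaker inhibition of growth), compound 1 gives 1900 nM, and this is the only outright number in the set. For compound 2 the result is a limit of the assay rather than a number, > 100000 nM; this is the case described by the limit of > 100000 nM in this assay, at which 1 of the 2 values shown sits. For the measured compounds named here, the two compounds differ in more than one place, so the gap between them says only that compound 1 inhibits growth and compound 2 gives no measurable inhibition within the range tested.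

The unmeasured compound 3, `COC(=O)C#CC(O/C=C/C(=O)OC)C(C)C`, is related to compound 1 by a single change: isopropyl in place of pentyl on a saturated chain carbon bound to an oxygen on an unsaturated carbon and a triple-bonded carbon. The alkynyl ester and the enol ester that compound 1 carries are kept. Going by the values given here, no step between two measured compounds covers this kind of change, so the expectation rests on compound 1 alone. Because compound 1 gives 1900 nM, compound 3 is expected to remain an active compound, with a modest shift toward weaker inhibition of growth, a step of a 2.4-fold higher number from compound 1 to compound 3 (0.37 log units; beyond the scatter) that is expected to sit at or just beyond the usual scatter. Compound 3 is therefore estimated at 4500 nM in this assay. Compound 3 should lie between 1500 nM and 15000 nM.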

Compound 3, concentration for 50% growth inhibition: 450 nM
The estimate for compound 3 lay 10-fold (1.00 log units) above the measured number, and the stated range ends above it.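

In this assay, the change of isopropyl in place of pentyl on a saturated chain carbon bound to an oxygen on an unsaturated carbon and a triple-bonded carbon gives a 4.2-fold lower number from compound 1 to compound 3 (0.63 log units; beyond the scatter). This shows that activity responds to the group at this position and that pentyl is not needed there: with the alkynyl ester and the enol ester kept, the group of 3 carbons gives the lower number of this pair. It is still a single step, so it sets no trend with chain size or shape, and nothing measured in this set accounts for the gain.

Compound 2 carries a limit of the assay rather than a number and differs from the others in more than one place, so it cannot place a smaller group on the same scale: the limit of > 100000 nM in this assay, at which 1 of the 3 values shown sits. The compounds shown leave open whether a tert-butyl group, a cyclohexyl ring, a phenyl ring or a chain ending in an amine at this position would give a lower or a higher number than isopropyl does.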